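Benzimidazole acetic acids: swapping the aryl group on the thioether

A few compounds are considered here, and "the series" means these few. Any claim that something is new, unique, unknown or untested is made for them only; others in the source may bear on it.

Measured compounds:
Compound 1 `CCOC(=O)CCSc1nc2ccccc2n1CC(=O)O` gives 11400 nM in an assay on HEK293 cells for displacement of a labelled ligand from prostaglandin D2 receptor 2 (Homo sapiens); a lower number here means a stronger inhibitor, a higher number a weaker inhibitor.
Compound 2 `O=C(O)Cn1c(SCc2ccc(Cl)cc2)nc2ccccc21` gives 160 nM in this assay.
Compound 3 `O=C(O)Cn1c(SCc2cccc(Cl)c2)nc2ccccc21` gives 186 nM in this assay.

Compound 3 sits second highest of the three numbers; its nearest neighbour is compound 2, which lies within the scatter of it, and the furthest is compound 1, which lies well beyond it. Compound 4 `Cc1ccccc1CSc1nc2ccccc2n1CC(=O)O` has not yet been measured. It differs from compound 3 in one place: 2-methylphenyl in place of 3-chlorophenyl on a saturated chain carbon bound to a sulfur.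

Going by the values given here, of the measured steps, the one most like this change is a 1.2-fold higher number from compound 2 to compound 3 (0.07 log units; within the scatter), which shows that moving the chlorine around the ring made no difference beyond the scatter. The large steps of a 71-fold lower number from compound 1 to compound 2 (1.85 log units; beyond the scatter) and a 61-fold lower number from compound 1 to compound 3 (1.79 log units; beyond the scatter) show that an aryl group in this place, rather than the (ethoxycarbonyl)methyl chain, is what carries the gain. Among the compounds with values here, no measured step shows a methyl in place of a chlorine, nor a 2-substituted ring, so that part rests on no data.

Compound 4 is therefore expected to stay close to compound 3, with a step of a 1.3-fold higher number from compound 3 to compound 4 (0.13 log units; within the scatter) that is within the scatter. The estimate for compound 4 is 250 nM, with a range from 90 nM to 700 nM.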

Compound 4, half-maximal inhibitory concentration: 810 nM
Beside the measured number, compound 4's estimate is 3.2-fold (0.51 log units) below it, outside the stated range (above it).
By their numbers in this assay, from the lowest: compounds 2 and 3 (each within the scatter of the next); then compound 4; then compound 1.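

In this assay, the aryl group on this saturated chain carbon bound to a sulfur proves not to be freely interchangeable: 2-methylphenyl gives a 4.4-fold higher number from compound 3 to compound 4 (0.64 log units; beyond the scatter) and a 5.1-fold higher number from compound 2 to compound 4 (0.70 log units; beyond the scatter), whereas the earlier exchange between 4-chlorophenyl and 3-chlorophenyl stayed within the scatter. The gain over the (ethoxycarbonyl)methyl chain nevertheless survives with an aryl group that carries no chlorine, with a 14-fold lower number from compound 1 to compound 4 (1.15 log units; beyond the scatter). Nothing measured here accounts for the weaker result with 2-methylphenyl.

Compound 4 differs from compound 2 and compound 3 both in the group on the aryl ring and in where that group stands, so these compounds cannot show which of the two changes accounts for the steps, and a 2-chlorophenyl or a 3-methylphenyl group would separate them. Going by these compounds, how an unsubstituted phenyl, a methoxy-bearing phenyl or a longer chain between the sulfur and the aryl group would read in this assay also remains open.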